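Compound 3: replacing methyl at the limit-bound end

The source may report more compounds than this note shows. Statements on the series, on what has been measured and on what is new or still open speak of the compounds shown alone.

In a physicochemical assay for solubility, read by chemiluminescence, measured as kinetic solubility (on this read-out lower numbers stand for lower solubility and higher numbers for higher solubility), compound 1 `COc1nn(C)c2cccc(NS(=O)(=O)c3cccc(Cl)c3Cl)c12` gives 80000 nM. Compound 2 `COc1nn(C)c2nc(C)nc(NS(=O)(=O)c3cccc(Cl)c3Cl)c12` gives >= 557000 nM, and this is a limit of the assay rather than a number. The two compounds differ in more than one place, so neither gives a clean single-change comparison. Compound 3 `COc1nn(C)c2nc(NC(C)C)nc(NS(=O)(=O)c3cccc(Cl)c3Cl)c12` carries isopropylamino in place of methyl on an aromatic carbon, between two ring nitrogen atoms (isopropylamino in place of methyl on an aromatic carbon). Among the measured compounds shown here, no measured pair isolates this change, and the starting point is only a limit, so the expectation remains loose. A fall in this assay beyond the usual scatter is expected, though a result that again reaches the limit remains possible. The estimated change is an at least 3.0-fold lower number from compound 2 to compound 3 (0.49 log units; beyond the scatter). For compound 3 the expected value is 180000 nM, with an estimated range of 50000 nM to 500000 nM.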

Compound 3, solubility: >= 551000 nM
Compound 3: no number, only a limit; the forecaster's own chance of this, stated with the estimate: 25%; middle value at least 3.0-fold (0.48 log units) away from the limit.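

Among the compounds shown here, compound 2 and compound 3 both stand at a limit of this assay rather than at a number, so no step between them can be read. The compounds shown leave open the size and direction of the change from methyl to isopropylamino.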